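Aryl Swap on a Shared Core: Estimating Compound 3

The compounds below may be only part of what the source reports. "The series", "measured", "known", "first", "only" and "open" are said of these compounds alone.

Compound 1 `C[C@H]1CC[C@@H]2[C@@H](OC(=O)[C@]23CC(c2ccc(Cl)cc2)=NO3)[C@]2(C)C(=O)C=C[C@@]12O`: 49000 nM
Compound 2 `COc1ccc(C2=NO[C@]3(C2)C(=O)O[C@@H]2[C@H]3CC[C@H](C)[C@]3(O)C=CC(=O)[C@@]23C)cc1OC`: 25000 nM

In a functional assay on PC-3 cells (Homo sapiens) for cytotoxicity, read by sulforhodamine B assay, with a stated time of 48 h (on this read-out higher numbers stand for weaker inhibition and lower numbers for stronger inhibition), compound 2 gives 25000 nM. Against compound 1 it shows only a 2.0-fold lower number from compound 1 to compound 2 (0.29 log units; within the scatter), so the two numbers stand together within the scatter. Compound 3 `C[C@H]1CC[C@@H]2[C@@H](OC(=O)[C@]23CC(c2ccc(C#N)cc2)=NO3)[C@]2(C)C(=O)C=C[C@@]12O` is the next variation at the same position: 4-cyanophenyl in place of 3,4-dimethoxyphenyl on a carbon with a double bond to nitrogen. Among the compounds with values here, the one measured step at this position, a 2.0-fold lower number from compound 1 to compound 2 (0.29 log units; within the scatter), was also an exchange of the aryl group and stayed within the scatter, so no step beyond the scatter is expected here either, a 1.2-fold higher number from compound 2 to compound 3 (0.08 log units; within the scatter). Compound 3 is therefore estimated at 30000 nM, with a range from 12000 nM to 75000 nM.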

Compound 3, half-maximal inhibitory concentration: 32000 nM
For compound 3 the middle estimate is 1.1-fold (0.03 log units) below the measured one, within the range that was stated.
By their numbers in this assay, from the lowest: compounds 2, 3 and 1 (each within the scatter of the next).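

In this assay, the exchange of 3,4-dimethoxyphenyl for 4-cyanophenyl gives a 1.3-fold higher number from compound 2 to compound 3 (0.11 log units; within the scatter), and the narrower exchange of chloro for cyano on the same aromatic carbon gives a 1.5-fold lower number from compound 1 to compound 3 (0.19 log units; within the scatter). A third aryl group, now carrying a nitrile, thus leaves all three compounds within the scatter of one another, so no exchange at this position has yet produced a step beyond it. Nothing further is available to explain these numbers.

The compounds shown leave open whether a carboxylic acid or an amine on the aromatic ring, or a longer alkyl chain in place of that ring, would move the number beyond the scatter.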